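Bromo in place of chloro on the 3-halophenyl

A few compounds are considered here, and "the series" means these few. Any claim that something is new, unique, unknown or untested is made for them only; others in the source may bear on it.

Compound 1 `O=[N+]([O-])c1ccc(N/C(=N\O)c2ccccc2Cl)c2nonc12` and compound 2 `O=[N+]([O-])c1ccc(N/C(=N\O)c2cccc(Cl)c2)c2nonc12` share one core and differ only in where the chloro group sits on the phenyl ring. In an assay on isolated protein for inhibition of Indoleamine 2,3-dioxygenase 1 (Homo sapiens), read by spectrophotometry, with a stated time of 1 h (on this read-out lower numbers stand for stronger inhibition and higher numbers for weaker inhibition), compound 1 gives 135 nM, and compound 2 gives 184 nM. Compound 2 stands at the upper end of the two numbers, but the step of a 1.4-fold higher number from compound 1 to compound 2 (0.13 log units; within the scatter) lies within the scatter, so the two compounds are not distinguished. Compound 3 `O=[N+]([O-])c1ccc(N/C(=N\O)c2cccc(Br)c2)c2nonc12` carries bromo in place of chloro on an aromatic carbon. Among the compounds with values here, no measured step exchanges one halogen for another; the only step available moves a chloro group between positions and stays within the scatter. Nothing in the measured pair points to a step beyond the scatter in this assay, in either direction. Compound 3 is therefore expected to give 180 nM in this assay, with a range of 90 nM to 360 nM. The expected step of a 1.0-fold lower number from compound 2 to compound 3 (0.01 log units; within the scatter) is estimated to stay within the scatter.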

Compound 3, half-maximal inhibitory concentration: 105 nM
The estimate for compound 3 lay 1.7-fold (0.23 log units) above the measured number, and the stated range covers the measured number.
By their numbers in this assay, from the lowest: compounds 3, 1 and 2 (each within the scatter of the next).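

In this assay the exchange of one halogen for another gives a 1.8-fold lower number from compound 2 to compound 3 (0.24 log units; within the scatter) and so stays within the scatter: on this aromatic carbon, bromo and chloro are not distinguished. The exchange of 2-chlorophenyl for 3-bromophenyl gives a 1.3-fold lower number from compound 1 to compound 3 (0.11 log units; within the scatter) and also stays within the scatter, so the three compounds cannot be told apart and no change of halogen or of its place on the phenyl ring shown so far gives a step beyond the scatter. No evidence bears on why these steps are small.

From the compounds shown here alone, whether a non-halogen group in place of bromo, such as an amine, a carboxylic acid or a longer chain, would give a step beyond the scatter remains open. Going by these compounds, the response to changes on the shared core, away from the phenyl ring, is also open.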